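Anilino to benzylamino on the shared core

The source may report more compounds than this note shows. Statements on the series, on what has been measured and on what is new or still open speak of the compounds shown alone.

Compound 1 `OC[C@H]1OC(n2cnc3c(Nc4ccccc4)nccc32)[C@H](O)[C@@H]1O` gives 4% in a functional assay (Homo sapiens) for inhibition of Nucleic Acid, tested at 100 uM; a lower number here means less inhibition, a higher number more inhibition at the concentration tested (going by the name of the read-out); this is the only number shown for it, and a further entry gives no single number. Compound 2 `OC[C@H]1O[C@@H](n2cnc3cnccc32)[C@H](O)[C@@H]1O` gives 13%; 1% (2 entries) in this assay, both entries within the usual scatter of each other (the several entries of compound 2 in this assay, 13%; 1% (2 entries)). Compound 3 `OC[C@H]1OC(n2cnc3c(NCc4ccccc4)nccc32)[C@H](O)[C@@H]1O` differs from compound 1 by benzyl in place of phenyl on a nitrogen on an aromatic ring. For the measured compounds named here, no step between measured compounds has been measured here, and both compounds 1 and 2 sit low in this assay. The expected step is a number 2 percentage points higher from compound 1 to compound 3 (within the scatter), none beyond the scatter. Compound 3 is estimated at 6%, between -5% and 20%.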

Compound 3, a percentage reported as inhibition, at one concentration (the size of the read-out at that concentration, not a potency): 32%
The estimate for compound 3 lay 26 percentage points below the measured number; measured number above the stated range.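

Benzyl in place of phenyl on a nitrogen on an aromatic ring gives a number 28 percentage points higher from compound 1 to compound 3 (beyond the scatter) in this assay and is the first measured step in this series. This position therefore responds to the change from anilino to benzylamino, although both groups carry the same carbon-only aromatic ring. The step remains modest and compound 3 has one entry, while repeat entries show how widely this read-out can spread: the several entries of compound 2 in this assay, 13%; 1% (2 entries).

Going by these compounds, it remains open whether a longer chain, such as phenethyl, extends the rise. Also open, on these data alone, is whether a carboxylic acid or an amine on the benzyl ring retains it.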